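A few compounds are considered here, and "the series" means these few. Any claim that something is new, unique, unknown or untested is made for them only; others in the source may bear on it.

Measured compounds:
compound 1, `CCN1CCc2c(c(C)nn2C(=O)Nc2ccc(Br)cc2)C1`: 59.7%
compound 2, `CCN1CCc2c(c(C)nn2C(=O)Nc2cccc(C(F)(F)F)c2)C1`: 56.1%

Both were tested in a functional assay on the whole organism (strain Swiss albino) for inhibition, with Mus musculus as the target, in the writhing test, with a stated time of 30 min, at a dose of 100 mg/kg; a higher number here means more inhibition at the dose given (going by the name of the read-out), a lower number less inhibition. Compound 1 gives 59.7% in this assay, and compound 2 gives 56.1%. Compound 1 stands at the top of the two numbers shown, but the number of compound 2 lies within the usual scatter of it, so the two compounds cannot be told apart on these data. Within the data shown here, no pair of measured compounds differs in one place only, so no measured step is available to guide an expectation.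

The compound not yet measured is compound 3, `CCN1CCc2c(c(C)nn2C(=O)Nc2ccc(Cl)cc2)C1`. It differs from compound 1 by one change: chloro in place of bromo on an aromatic carbon. The change is small, exchanging one halogen for another at the same aromatic carbon, and the two measured compounds, which carry different substituents on the same ring, already sit within the scatter of each other. The step from compound 1 to compound 3 in this assay is therefore expected to be a number 3.7 percentage points lower from compound 1 to compound 3 (within the scatter), that is, nothing beyond the scatter in either direction. Compound 3 is estimated to give 56% in this assay, with a range from 42% to 68%.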

Compound 3, a percentage reported as inhibition, in the whole organism at one dose (the size of the read-out at that dose, not a potency): 55.2%
The estimate for compound 3 lay 0.8 percentage points above the measured number; low and high end bracket the measured number.
By their numbers in this assay, from the lowest: compounds 3, 2 and 1 (each within the scatter of the next).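

Among these compounds, the exchange of bromo for chloro on an aromatic carbon, para to a large group, supplies the first measured step between two compounds that differ in one place: in this assay there is a number 4.5 percentage points lower from compound 1 to compound 3 (within the scatter). Among the compounds shown here, until now, the only comparison available was between two compounds that carry different substituents at different places on the ring, and it could say nothing about a single position taken alone. At this position, the read-out at this one dose does not separate the 4-bromophenyl from the 4-chlorophenyl, and nothing measured here bears on what lies behind this result.

The compounds shown leave open whether this position accepts groups of another kind, such as a methoxy group, an amine or a carboxylic acid, and whether a plain phenyl with no substituent at all would give a number within the same scatter. They also leave open whether the two halogens would stay indistinguishable at other doses, since each reading here comes from a single dose and gives no measure of potency.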